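Tert-Butoxy Ether in Place of a Spiro Amine

The source may hold more compounds than are shown below. What is called first, only, known or untested is meant among the compounds shown, and "the series" means these compounds.

Compound 1, `COc1ccc2[nH]c(C(=O)N3CC(=O)N(Cc4ccccc4)[C@@H](CN4CCCCC4)C3)cc2c1`; in a physicochemical assay for solubility, read by spectrophotometry, in phosphate buffer, with a stated time of 2 h, at pH 7.4 (a lower number here means a less soluble compound, a higher number a more soluble compound), compound 1 gives > 25000 nM, which is a limit of the assay.
Compound 2, `COc1ccc2[nH]c(C(=O)N3CC(=O)N(Cc4ccccc4)[C@@H](COCc4ccccc4)C3)cc2c1`; in this assay compound 2 gives 8800 nM.
Compound 3, `COc1ccc2[nH]c(C(=O)N3CC(=O)N(Cc4ccccc4)[C@@H](CCN4CCC5(CC4)CC5)C3)cc2c1`; in this assay compound 3 gives > 25000 nM, again a limit.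

Compound 3 stands at the limit of > 25000 nM in this assay, at which 2 of the 3 values shown sit, and compound 1 stands there as well, so the step that the two limits leave unreadable from compound 1 to compound 3 cannot be read. Against compound 2 the step of an at least 2.8-fold higher number from compound 2 to compound 3 (0.45 log units; beyond the scatter) is readable and runs toward the limit. The new compound 4, `COc1ccc2[nH]c(C(=O)N3CC(=O)N(Cc4ccccc4)[C@@H](COC(C)(C)C)C3)cc2c1`, carries a group of 5 heavy atoms (4 carbon, 1 oxygen; no ring) in place of a group of 9 heavy atoms (8 carbon, 1 nitrogen; one three-membered non-aromatic ring of carbon only, one six-membered non-aromatic ring with 1 hetero atom), on a saturated chain carbon bound to a saturated ring carbon. This is a move from an amine to an ether on the same chain carbon, the same kind of move as in an at least 2.8-fold lower number from compound 1 to compound 2 (0.45 log units; beyond the scatter), which took the number down off the limit and beyond the scatter. For the ether compound 4 the step of an at least 2.0-fold lower number from compound 3 to compound 4 (0.31 log units; beyond the scatter) is therefore expected to lower the number in this assay. Compound 4 is estimated at 12000 nM, with a range of 5000 nM to 25000 nM.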

Compound 4, solubility: 65500 nM
Estimate against measurement, compound 4: 5.5-fold (0.74 log units) below, outside the stated range (above it).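

The two ethers do not behave alike: with tert-butyl in place of benzyl on an oxygen on a saturated carbon, the step in this assay is a 7.4-fold higher number from compound 2 to compound 4 (0.87 log units; beyond the scatter). The amine-to-ether change therefore does not by itself give a low number, since compound 2 and compound 4 are both ethers and differ in the group on that oxygen. The steps to compound 4 from compound 1 and from compound 3 cannot be read, because both of those compounds sit at a limit: the limit of > 25000 nM in this assay, at which 2 of the 4 values shown sit.

Going by these compounds, how far the amines of compound 1 and compound 3 really stand from tert-butoxy therefore stays open. Also open, on these data alone, is where a smaller ether such as methoxy, or a carboxylic acid, on the same chain carbon would fall in this assay.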